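The source may hold more compounds than are shown below. What is called first, only, known or untested is meant among the compounds shown, and "the series" means these compounds.

Of the compounds shown here, three have been tested in a functional assay on SF-268 cells (Homo sapiens) for cytotoxicity, read by sulforhodamine B assay, with a stated time of 48 h, tested at 100 uM; a higher number here means a weaker effect of the compound at the concentration tested, a lower number a stronger effect. Compound 1 `COc1ccc(-c2cc(/C=C/C(=O)c3ccc(N)cc3)[nH]n2)cc1` gives -61% in this assay. Compound 2 `COc1ccc(-c2cc(/C=C/C(=O)c3ccc(N)cc3)[nH]n2)cc1OC` gives -80% in this assay. Compound 1 arises from compound 2 by hydrogen in place of methoxy on an aromatic carbon, and this change made a step of a number 19 percentage points higher from compound 2 to compound 1 (beyond the scatter). Compound 3 `COc1cc(C(=O)/C=C/c2cc(-c3cc(OC)c(OC)c(OC)c3)n[nH]2)cc(OC)c1OC` gives -75% in this assay; the difference between its core and the core of compound 2 is not broken down here.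

Compound 4 `COc1ccc(-c2cc(/C=C/C(=O)c3cc(OC)c(OC)c(OC)c3)[nH]n2)cc1OC` has not yet been measured. It arises from compound 3 by hydrogen in place of methoxy on an aromatic carbon. Among the compounds with values here, this is the same kind of change as the one from compound 2 to compound 1, but not the same: in compound 3 the carbon that loses its methoxy group is also meta to a methoxy group, which is not so in compound 2. The change is seen only once among the measured compounds. If it behaves similarly, compound 4 is expected to give -58% in this assay. The expected step of a number 17 percentage points higher from compound 3 to compound 4 (beyond the scatter) rests on the measured step of a number 19 percentage points higher from compound 2 to compound 1 (beyond the scatter), widened for the different surroundings. The expected range for compound 4 runs from -78% to -38%.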

Compound 4, a percentage reported as activity, at one concentration (the size of the read-out at that concentration, not a potency): -72%
For compound 4 the middle estimate is 14 percentage points above the measured one; the measured number falls inside the stated range.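

In this assay, hydrogen in place of a methoxy group on an aromatic carbon gives a step of a number 3 percentage points higher from compound 3 to compound 4 (within the scatter), so on this core the swap leaves no readable change. The same swap therefore cannot be carried from one core to the other at a fixed size, as the two steps differ: the same change on two cores in this assay, a number 19 percentage points higher (beyond the scatter) from compound 2 to compound 1 and a number 3 percentage points higher (within the scatter) from compound 3 to compound 4, 16 percentage points apart, beyond the scatter of two such steps

This shows that, for these two pairs, the size of the step depends on the core that carries the change, but it does not show which feature of the cores matters, and two pairs give no rule for predicting a third core.

Among the compounds shown, only hydrogen and methoxy stand at this place, which leaves open how a hydroxyl group or a chlorine atom there would read on either core. From the compounds shown here alone, it also remains open whether taking away further methoxy groups from the core of compound 4 would give a step beyond the scatter.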